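Replacing 2-chlorophenyl with 4-cyanophenyl in compound 2

The source may report more compounds than this note shows. Statements on the series, on what has been measured and on what is new or still open speak of the compounds shown alone.

Compound 1 `CC/C(=C(/c1ccc(/C=C/C(=O)O)cc1)c1ccc(NS(C)(=O)=O)cc1)c1ccccc1` gives 2310 nM
Compound 2 `CC/C(=C(/c1ccc(/C=C/C(=O)O)cc1)c1ccc2[nH]ncc2c1)c1ccccc1Cl` gives 2 nM

Both numbers come from a functional assay on MCF7 cells (Homo sapiens) for cytotoxicity, read by CellTiter-Glo, with a stated time of 5 days (a higher number here means a weaker inhibitor, a lower number a stronger inhibitor), and they sit very far apart. Compound 2 has the lower of the two numbers, and its gap to compound 1 lies well beyond the scatter of repeated measurements. The two compounds differ in more than one place, so that gap cannot be pinned on any single group.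

Compound 3 `CC/C(=C(/c1ccc(/C=C/C(=O)O)cc1)c1ccc2[nH]ncc2c1)c1ccc(C#N)cc1` has not been measured yet. Compared with compound 2, it has 4-cyanophenyl in place of 2-chlorophenyl on a double-bonded chain carbon bound to a double-bonded chain carbon and a saturated chain carbon. Among the measured compounds shown here, no measured pair shows this swap on its own, so any forecast is a judgement. For the measured compounds named here, compound 2 at 2 nM is the lower of only two values, so a modest rise in the number seems likelier than a further drop. The estimated change is a 4.0-fold higher number from compound 2 to compound 3 (0.60 log units; beyond the scatter) and it may only just clear the scatter. The value expected for compound 3 is 8 nM with 1.5 nM to 45 nM as the estimated range.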

Compound 3, half-maximal inhibitory concentration: 47 nM
For compound 3 the middle estimate is 5.9-fold (0.77 log units) below the measured one, outside the stated range (above it).
By their numbers in this assay, from the lowest: compound 2; then compound 3; then compound 1.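

In this assay, putting 4-cyanophenyl in place of 2-chlorophenyl gives a 24-fold higher number from compound 2 to compound 3 (1.37 log units; beyond the scatter), so the ring on this double-bonded chain carbon, bound to a double-bonded chain carbon and a saturated chain carbon, has a large bearing on the number. This is the first pair shown that differs in one place only, so this gap, unlike the one between compound 1 and compound 2, can be tied to a single change. Nothing measured here speaks to the cause of the rise.

The swap alters two things at once, the substituent, from chlorine to nitrile, and its numbered place on the ring, and the compounds shown cannot tell which of the two carries the step. Also open, going by these compounds, is whether a fluorine or a methoxy group in the place of the chlorine would keep the number close to that of compound 2 at 2 nM, or whether the low value depends on the chlorine itself.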